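This account rests on a few compounds, and the source may have more. Where it says the series, first, only, none or still open, it means among the compounds named here.

Compound 2 `O=C(NC(=S)Nc1ccc(Cl)cc1)c1cn(-c2ccccc2)nc1-c1ccccc1` carries a plain phenyl on the shared core, and in a functional assay on A549 cells (Homo sapiens) for inhibition, read by CCK-8 assay, with a stated time of 48 h (on this read-out higher numbers stand for weaker inhibition and lower numbers for stronger inhibition), compound 2 gives 3200 nM. For the measured compounds named here, of the two numbers known so far, compound 2 has nominally the higher, but compound 1 `Cc1ccc(-c2nn(-c3ccccc3)cc2C(=O)NC(=S)Nc2ccc(Cl)cc2)cc1` lies within the scatter of it: in this assay compound 1 gives 3170 nM, and the only step known, a 1.0-fold higher number from compound 1 to compound 2 (0.00 log units; within the scatter), moved nothing beyond the scatter. Compound 3 `O=C(NC(=S)Nc1ccc(Cl)cc1)c1cn(-c2ccccc2)nc1-c1ccc(F)cc1` is the next step out from compound 2: fluoro in place of hydrogen on an aromatic carbon. The step between compound 1 and compound 2 bears on it, since that step also exchanged one small group on an aromatic carbon of a six-membered aromatic ring of carbon only, and it was flat. A single flat step is thin evidence, but nothing here points either way, so the expected step of no change at the digits printed from compound 2 to compound 3 (within the scatter) is none beyond the scatter. Compound 3 is therefore estimated at 3200 nM, with a range from 1500 nM to 6800 nM.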

Compound 3, half-maximal inhibitory concentration: 2990 nM
Compound 3: middle estimate off by 1.1-fold (0.03 log units), on the high side; the measured number falls inside the stated range.
By their numbers in this assay, from the lowest: compounds 3, 1 and 2 (each within the scatter of the next).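

Replacing hydrogen with fluoro, which turns phenyl into 4-fluorophenyl, gives a 1.1-fold lower number from compound 2 to compound 3 (0.03 log units; within the scatter) in this assay. Replacing methyl with fluoro on the same aromatic carbon, para to a large group, gives a 1.1-fold lower number from compound 1 to compound 3 (0.03 log units; within the scatter), so hydrogen, methyl and fluoro at this position now all read alike, where before only hydrogen and methyl could be compared. Nothing available explains why these three groups give such similar numbers.

From the compounds shown here alone, it remains open whether this flat picture would hold for groups of a different kind at this position, such as an amine, a carboxylic acid or a longer alkyl chain. Going by these compounds, it is also open whether fluoro or methyl would read the same on other carbons of this ring, or with other parts of the shared core changed.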